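Swapping a branched amine for a piperidine ring

This account rests on a few compounds, and the source may have more. Where it says the series, first, only, none or still open, it means among the compounds named here.

Of the compounds shown here, three sharing one core have been measured in a physicochemical assay for lipophilicity; a higher number here means a more lipophilic compound, a lower number a more polar compound. Compound 1 `NS(=O)(=O)Oc1ccc2c(c1)CN(C(=O)c1ccc(N(Cc3ccccc3)Cc3ccco3)cc1)CC2` gives 1.93, compound 2 `NS(=O)(=O)Oc1ccc2c(c1)CN(C(=O)c1ccc(N3CCN(Cc4ccccc4)CC3)cc1)CC2` gives 1.93, and compound 3 `CC(C)CCN(CCC(C)C)c1ccc(C(=O)N2CCc3ccc(OS(N)(=O)=O)cc3C2)cc1` gives 1.93. These three values lie within the scatter of one another, so no order can be read among them, and compound 3 stands level with both of its neighbours.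

Compound 4 `NS(=O)(=O)Oc1ccc2c(c1)CN(C(=O)c1ccc(N3CCCCC3)cc1)CC2` has not been measured. It differs from compound 3 in one place: piperidin-1-yl in place of diisopentylamino on an aromatic carbon. Within the data shown here, no step between measured pairs is available, so the expected size must be judged from the three values alone. Because compound 1 gives 1.93 and compound 2 gives 1.93, very different amine substituents have so far produced no visible change, which argues for a modest shift at most; a smaller group is nevertheless expected to lower the number somewhat, by a number 0.33 log units lower from compound 3 to compound 4 (beyond the scatter). Compound 4 is therefore estimated at 1.6, with a plausible range from 0.9 to 2.2.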

Compound 4, partition coefficient: 1.93
For compound 4 the middle estimate is 0.33 log units below the measured one, within the range that was stated.
By their numbers in this assay, from the lowest: compounds 1, 2, 3 and 4 (each within the scatter of the next).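

Among these compounds, this is the first comparison in which only the group on this aromatic carbon, para to a large group, differs. In this assay, piperidin-1-yl in place of diisopentylamino gives no change at the digits printed from compound 3 to compound 4 (within the scatter), even though 11 heavy atoms with no ring give way to 6 heavy atoms in a six-membered non-aromatic ring. For this pair, then, neither the loss of those heavy atoms nor the closing of a ring shows up in the read-out, and nothing available explains why.

Still open, from the compounds shown here alone, is whether a much shorter substituent, such as dimethylamino, would leave the number where it stands at this position. Going by these compounds, it is also open whether a group of a different kind here, such as morpholin-4-yl or a carboxylic acid, would shift the reading in this assay beyond the scatter.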